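Swapping one halogenated benzyl group for another

The compounds below may be only part of what the source reports. "The series", "measured", "known", "first", "only" and "open" are said of these compounds alone.

Measured compounds:
Compound 1, `O=C1c2sccc2N(Cc2ccccc2Cl)S(=O)(=O)N1Cc1ccccc1`, in an ADME assay on MT4 cells (Homo sapiens) for cytotoxicity, read by MTT assay, with a stated time of 4 days (a higher number here means that more compound is tolerated, a lower number that less compound is tolerated), gives > 298000 nM, a limit of the assay rather than a number.
Compound 2, `N#Cc1ccccc1CN1c2ccsc2C(=O)N(Cc2ccccc2)S1(=O)=O`, in this assay gives > 305000 nM, also a limit.
Compound 3, `O=C1c2sccc2N(Cc2ccc(Cl)cc2Cl)S(=O)(=O)N1Cc1ccccc1`, in this assay gives 247000 nM.

Compound 1 stands only at a limit in this assay, (the limit of > 298000 nM in this assay, at which 1 of the 3 values shown sits), so its true tolerance is not pinned down. Compound 2 stands at a limit as well, (the limit of > 305000 nM in this assay, at which 1 of the 3 values shown sits). Compound 4, `O=C1c2sccc2N(Cc2ccc(Br)cc2)S(=O)(=O)N1Cc1ccccc1`, has not yet been measured; it differs from compound 1 by 4-bromophenyl in place of 2-chlorophenyl on a saturated chain carbon bound to a sulfonamide nitrogen in a ring. The measured steps give little to work with: a step that the two limits leave unreadable from compound 1 to compound 2, while an at least 1.2-fold lower number from compound 1 to compound 3 (0.08 log units; that floor lies within the scatter) and an at least 1.2-fold lower number from compound 2 to compound 3 (0.09 log units; that floor lies within the scatter) are both floors that stay within the usual scatter. None of the three measured compounds shows a tolerance clearly different from the others. The step of an at least 1.1-fold lower number from compound 1 to compound 4 (0.04 log units; that floor lies within the scatter) is therefore expected to be small or none beyond the scatter. Compound 4 is estimated at 270000 nM, with a range from 140000 nM to 400000 nM.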

Compound 4, half-maximal cytotoxic concentration: 6600 nM
Compound 4: the middle estimate sits 41-fold (1.61 log units) above what was measured, outside the stated range (below it).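

Across the four compounds, this place on a saturated chain carbon bound to a sulfonamide nitrogen in a ring turns out not to be silent in this assay: compound 4 alone stands apart, with an at least 45-fold lower number from compound 1 to compound 4 (1.65 log units; beyond the scatter), an at least 46-fold lower number from compound 2 to compound 4 (1.66 log units; beyond the scatter) and a 37-fold lower number from compound 3 to compound 4 (1.57 log units; beyond the scatter). The step that starts at compound 1 is only a floor, because compound 1 gives a limit of the assay and not a number: the limit of > 298000 nM in this assay, at which 1 of the 4 values shown sits. The step that starts at compound 2 is a floor for the same reason, because compound 2 also gives a limit: the limit of > 305000 nM in this assay, at which 1 of the 4 values shown sits.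

The change from compound 1 to compound 4 alters both the halogen and its place on the ring, and the compounds shown do not separate the two. From the compounds shown here alone, how a plain phenyl group, or iodine in place of the bromine, would stand in this assay also stays open.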